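Piperazinyl carbonyl in place of 4-fluorophenyl on the shared core

This account rests on a few compounds, and the source may have more. Where it says the series, first, only, none or still open, it means among the compounds named here.

Compound 3 `O=C(CCCCCCc1ccccc1)c1ncc(-c2ccc(F)cc2)o1` holds the lowest of the three numbers in an assay (Rattus norvegicus) for inhibition of Fatty-acid amide hydrolase 1 (Homo sapiens) (a lower number here means a stronger inhibitor, a higher number a weaker inhibitor), giving 62 nM. Compound 1 `NS(=O)(=O)c1ccccc1-c1cnc(C(=O)CCCCCCc2ccccc2)o1` gives 1500 nM and compound 2 `O=C(CCCCCCc1ccccc1)c1ncc(-c2ccccc2C(=O)C(F)(F)F)o1` gives 5000 nM, both well beyond the scatter from compound 3. For the measured compounds named here, the single measured step, a 3.3-fold higher number from compound 1 to compound 2 (0.52 log units; beyond the scatter), exchanges one group on an aromatic carbon while the ring itself stays, so it speaks only loosely to compound 4 `CN1CCN(C(=O)c2cnc(C(=O)CCCCCCc3ccccc3)o2)CC1`, whose change is (4-methylpiperazin-1-yl)carbonyl in place of 4-fluorophenyl on an aromatic carbon. Going by the values given here, no measured step removes the ring altogether. Both compounds that depart from the 4-fluorophenyl of compound 3, compound 1 with 1500 nM and compound 2 with 5000 nM, gave higher numbers. Compound 4 is therefore expected to be weaker, a 16-fold higher number from compound 3 to compound 4 (1.21 log units; beyond the scatter). Compound 4 is estimated at 1000 nM, within 150 nM to 6000 nM.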

Compound 4, inhibition constant: 80 nM
Estimate against measurement, compound 4: 13-fold (1.10 log units) above; the whole stated range lies above it.
By their numbers in this assay, from the lowest: compounds 3 and 4 (each within the scatter of the next); then compound 1; then compound 2.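

The 4-fluorophenyl is not needed at this position, next to the ring oxygen: with (4-methylpiperazin-1-yl)carbonyl there, a 1.3-fold higher number from compound 3 to compound 4 (0.11 log units; within the scatter). Compounds 1, 2 and 3 all carry a six-membered aromatic ring of carbon here, whereas compound 4 shows that a non-aromatic ring with 2 hetero atoms, joined through a carbonyl, also fits this series. Nothing available explains this result.

Open, as far as these compounds go, is whether the carbonyl or the methyl on the piperazine matters, since neither is separated from the ring. Also open, from the compounds shown here alone, is how a carboxylic acid or a primary amine would read at this position.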